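A few compounds are considered here, and "the series" means these few. Any claim that something is new, unique, unknown or untested is made for them only; others in the source may bear on it.

Measured compounds and their values:
Compound 1, `O=C1O[C@H]([C@@H](O)Cn2cc(-c3cc(F)cc(F)c3)nn2)C(OCc2ccccc2)=C1OCc1ccccc1`: 11600 nM
Compound 2, `O=C1O[C@H]([C@@H](O)Cn2cc(CNS(=O)(=O)c3ccc(F)cc3)nn2)C(OCc2ccccc2)=C1OCc1ccccc1`: 18300 nM
Compound 3, `C[Si](C)(C)c1cn(C[C@H](O)[C@H]2OC(=O)C(OCc3ccccc3)=C2OCc2ccccc2)nn1`: 24100 nM

All three were tested in a functional assay on HepG2 cells (Homo sapiens) for antiproliferative activity, read by MTT assay, with a stated time of 72 h; a lower number here means a stronger inhibitor, a higher number a weaker inhibitor. Compound 3 stands at the highest of the three numbers, though the step of a 1.3-fold higher number from compound 2 to compound 3 (0.12 log units; within the scatter) is within the scatter, and only a 2.1-fold higher number from compound 1 to compound 3 (0.32 log units; beyond the scatter) lies modestly beyond it. Compound 4 `O=C1O[C@H]([C@@H](O)Cn2cc(CCO)nn2)C(OCc2ccccc2)=C1OCc1ccccc1` has not yet been measured. It differs from compound 3 in one place: a group of 3 heavy atoms (2 carbon, 1 oxygen; no ring) in place of a group of 4 heavy atoms (3 carbon, 1 silicon; no ring), on an aromatic carbon. Going by the values given here, no measured step replaces exactly this group, but every measured step exchanges the group on that same aromatic carbon, and a 1.6-fold higher number from compound 1 to compound 2 (0.20 log units; within the scatter), a 2.1-fold higher number from compound 1 to compound 3 (0.32 log units; beyond the scatter) and a 1.3-fold higher number from compound 2 to compound 3 (0.12 log units; within the scatter) together show that changes at this position have so far shifted the number only slightly, all within a narrow band. The expectation for compound 4 is therefore a step of a 1.0-fold higher number from compound 3 to compound 4 (0.02 log units; within the scatter), that is, no change beyond the scatter in either direction. Compound 4 is estimated at 25000 nM, with a likely range from 10000 nM to 60000 nM.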

Compound 4, half-maximal inhibitory concentration: 68100 nM
The estimate for compound 4 lay 2.7-fold (0.44 log units) below the measured number; the measured number lies above the stated range.
By their numbers in this assay, from the lowest: compounds 1, 2 and 3 (each within the scatter of the next, the first and the last beyond it); then compound 4.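

Going by these compounds alone, the position is not as flat as the earlier compounds suggested: in this assay, 2-hydroxyethyl gives a 2.8-fold higher number from compound 3 to compound 4 (0.45 log units; beyond the scatter), and the other two comparisons, a 3.7-fold higher number from compound 2 to compound 4 (0.57 log units; beyond the scatter) and a 5.9-fold higher number from compound 1 to compound 4 (0.77 log units; beyond the scatter), are also beyond the scatter, which sets compound 4 apart as the weakest of the four. Heavy-atom count alone does not account for this, since the leaving and entering groups are close in size, whereas the much larger groups of compound 1 and compound 2 lie on the stronger side of compound 4. The entering group carries a hydrogen-bond donor and acceptor that the leaving group lacks, but compound 2 also has a donor in its group, and nothing available explains the loss.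

As far as these compounds go, it remains open whether the step follows the hydroxyl or the short chain itself. A 2-methoxyethyl, a 3-hydroxypropyl or a 2-aminoethyl group on the same aromatic carbon would help tell these apart.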